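A few compounds are considered here, and "the series" means these few. Any claim that something is new, unique, unknown or untested is made for them only; others in the source may bear on it.

Measured so far in an in vivo ADME assay on the whole organism (Cavia porcellus); on this read-out higher numbers stand for a longer-lived compound and lower numbers for a shorter-lived compound:

- Compound 1 `CCCC(NC(=O)c1ccc(C(=N)N)cc1)C(C)(C)C(=O)N1CCC(CC(=O)O)CC1` gives 0.9 h
- Compound 2 `C/C=C/C(NC(=O)c1ccc(C(=N)N)cc1)C(C)(C)C(=O)N1CCC(CC(=O)O)CC1` gives 0.933 h

Within the data shown here, these are the only two numbers available, and compound 2, at 0.933 h, cannot be told apart from compound 1, because the gap between them is a 1.0-fold higher number from compound 1 to compound 2 (0.02 log units; within the scatter). Repeat measurements of a half-life would be expected to differ by that much on their own.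

The next compound is compound 3 `CC(C)CC(NC(=O)c1ccc(C(=N)N)cc1)C(C)(C)C(=O)N1CCC(CC(=O)O)CC1`. It carries isobutyl in place of prop-1-en-1-yl on a saturated chain carbon bound to an amide-type nitrogen and a saturated chain carbon.

Among the measured compounds shown here, only one measured step bears on this change, and it concerns the same place on the molecule: prop-1-en-1-yl in place of propyl, which gave a 1.0-fold higher number from compound 1 to compound 2 (0.02 log units; within the scatter). For the measured compounds named here, no measured compound yet carries isobutyl, so this single step is thin evidence. Even so, it gives no reason to expect a real shift in this assay. The expected result is a 1.0-fold lower number from compound 2 to compound 3 (0.02 log units; within the scatter), which would stay within the scatter. For compound 3 the estimated half-life is 0.9 h, with an expected range from 0.5 h to 1.6 h.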

Compound 3, half-life: 0.917 h
The estimate for compound 3 lay 1.0-fold (0.01 log units) below the measured number; measured number inside the range.
By their numbers in this assay, from the lowest: compounds 1, 3 and 2 (each within the scatter of the next).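

Replacing prop-1-en-1-yl with isobutyl on this saturated chain carbon removes the double bond outside aromatic rings and raises the group from 3 to 4 heavy atoms, yet this assay records a 1.0-fold lower number from compound 2 to compound 3 (0.01 log units; within the scatter), so neither change registers on this read-out. The comparison with the straight chain adds a second test at the same place: methyl in place of hydrogen on a saturated chain carbon bound to two saturated chain carbons, which turns propyl into isobutyl, gives a 1.0-fold higher number from compound 1 to compound 3 (0.01 log units; within the scatter), so adding this branch does not separate the two compounds either. The straight, unsaturated and branched groups therefore cannot be told apart here, and no measurement is available to explain this result.

As far as these compounds go, all three groups consist only of carbon and hydrogen, so it remains open whether an amine, a hydroxyl or a carboxylic acid at this place would shift the half-life. From the compounds shown here alone, it is equally open whether a phenyl ring or a longer chain such as hexyl would do so, since these three compounds cover only a narrow range of group size and shape.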